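Methyl-for-hydrogen step repeated on a second core

The source may hold more compounds than are shown below. What is called first, only, known or untested is meant among the compounds shown, and "the series" means these compounds.

Measured compounds:
compound 1, `COc1cccc(N2CCN(C(=O)C(C)N3C(=O)CCC3=O)CC2)c1`: 75%
compound 2, `CCC(C(=O)N1CCN(c2cccc(OC)c2)CC1)N1C(=O)CCC1=O`: 25%
compound 3, `CC(C(=O)N1CCN(c2ccccc2C(F)(F)F)CC1)N1C(=O)CCC1=O`: 100%

All three were run in a functional assay on the whole organism (strain Swiss) with Mus musculus as the target, in the maximal electroshock model, with a stated time of 0.25 h, at a dose of 300 mg/kg by the intraperitoneal route; on this read-out higher numbers stand for a stronger effect at the one dose given and lower numbers for a weaker effect. Compound 1 gives 75% in this assay. Compound 2 carries methyl in place of hydrogen on a saturated chain carbon, two bonds along the chain from an amide-type nitrogen in a ring and a carbonyl carbon and gives 25%, so the change brought a number 50 percentage points lower from compound 1 to compound 2 (beyond the scatter). Compound 3 gives 100%, the highest of the three, standing beyond the scatter from both compound 1 and compound 2. The difference between the core of compound 1 and the core of compound 3 is not broken down here.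

Compound 4, `CCC(C(=O)N1CCN(c2ccccc2C(F)(F)F)CC1)N1C(=O)CCC1=O`, is not yet measured. It carries methyl in place of hydrogen on a saturated chain carbon, two bonds along the chain from an amide-type nitrogen in a ring and a carbonyl carbon, the same change as from compound 1 to compound 2, at a place described in identical words. On this single precedent the step from compound 3 to compound 4 is expected to be a number 50 percentage points lower from compound 3 to compound 4 (beyond the scatter), because from compound 1 to compound 2 the same change gave a number 50 percentage points lower from compound 1 to compound 2 (beyond the scatter). Compound 3 starts at a high read-out, so the room downward is wide. Compound 4 is therefore estimated at 50%, with a range from 25% to 100%.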

Compound 4, a percentage reported as activity, at one dose (the size of the read-out at that dose, not a potency): 25%
Compound 4: middle estimate off by 25 percentage points, on the high side, and the stated range covers the measured number.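

In this assay, the methyl-for-hydrogen change on the second core gave a number 75 percentage points lower from compound 3 to compound 4 (beyond the scatter), so the direction seen on the first core carries over, with a loss on both cores. The size of the step does not carry over unchanged, and a step read from one core is only a rough guide to the other: the same change on two cores in this assay, a number 50 percentage points lower (beyond the scatter) from compound 1 to compound 2 and a number 75 percentage points lower (beyond the scatter) from compound 3 to compound 4, 25 percentage points apart, beyond the scatter of two such steps These two pairs show neither why the size differs nor how large the step would be on a third core, and a read-out at one dose and one time says nothing about potency.

Still open, from the compounds shown here alone, is whether the loss continues or levels off with a longer chain at the same saturated chain carbon, such as propyl or isopropyl. Equally open, going by these compounds, is whether a chain of the same length carrying a hydroxyl group behaves like the ethyl of compound 2 and compound 4, and whether the change costs as much on a core with a different group on the aromatic ring, such as chlorine.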